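This account rests on a few compounds, and the source may have more. Where it says the series, first, only, none or still open, it means among the compounds named here.

Measured so far in an assay on CHO cells for displacement of a labelled ligand from Substance-P receptor (Homo sapiens); on this read-out higher numbers stand for weaker inhibition and lower numbers for stronger inhibition:
compound 1, `C[C@@H](O[C@@H]1CN(C(=O)[C@@H]2COC(=O)N2)C[C@H]1c1ccc(F)cc1)c1cc(C(F)(F)F)cc(C(F)(F)F)c1`: 0.34 nM
compound 2, `CCNC(=O)N1C[C@@H](O[C@H](C)c2cc(C(F)(F)F)cc(C(F)(F)F)c2)[C@H](c2ccc(F)cc2)C1`: 0.1 nM

Compound 2 holds the lowest of the two numbers in this assay; its nearest neighbour is compound 1, and the step of a 3.4-fold lower number from compound 1 to compound 2 (0.53 log units; beyond the scatter) lies beyond the scatter. Compound 3, `C[C@@H](O[C@@H]1CN(C(=O)NC(C)(C)C)C[C@H]1c1ccc(F)cc1)c1cc(C(F)(F)F)cc(C(F)(F)F)c1`, is not yet measured in this assay. It differs from compound 2 by tert-butyl in place of ethyl on an amide-type nitrogen. Among the measured compounds shown here, the only step on record, a 3.4-fold lower number from compound 1 to compound 2 (0.53 log units; beyond the scatter), exchanges the whole group on the carbonyl carbon rather than the substituent on the amide-type nitrogen, so it bears on the present change only loosely; no measured pair varies the alkyl group on that nitrogen, and the size of the coming step therefore has to be guessed from the general stability of this end of the molecule so far. On that limited basis the expected step in this assay is small, most likely within the scatter and without a clear direction: a 1.5-fold higher number from compound 2 to compound 3 (0.18 log units; within the scatter). For compound 3 the estimate in this assay is 0.15 nM, with a range from 0.04 nM to 0.6 nM.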

Compound 3, half-maximal inhibitory concentration: 0.14 nM
For compound 3 the middle estimate is 1.1-fold (0.03 log units) above the measured one; the measured number falls inside the stated range.
By their numbers in this assay, from the lowest: compounds 2 and 3 (each within the scatter of the next); then compound 1.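

In this assay, the change on the amide-type nitrogen gives a 1.4-fold higher number from compound 2 to compound 3 (0.15 log units; within the scatter), so ethyl and tert-butyl, with 2 and 4 carbons, cannot be told apart at this position despite the larger group. Among the compounds shown here, this is the first direct reading of the alkyl group on that nitrogen, as the earlier step exchanged the whole group on the carbonyl carbon. The second alkylamino group also stands apart from the 2-oxo-1,3-oxazolidin-4-yl group, with a 2.4-fold lower number from compound 1 to compound 3 (0.39 log units; beyond the scatter) alongside a 3.4-fold lower number from compound 1 to compound 2 (0.53 log units; beyond the scatter), so in these two pairs the lower number does not depend on which of the two alkyl groups is present; no available evidence explains the result or bears on it.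

The compounds shown leave open whether this level holds with a phenyl ring, a longer chain ending in an amine, or a carboxylic acid on the amide-type nitrogen, as both alkyl groups shown are small and carry no further functional group. They also leave open what happens when a methyl group takes the place of the amide hydrogen.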